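Cyclopropyl amides on the shared core: a stereoisomer

The source may report more compounds than this note shows. Statements on the series, on what has been measured and on what is new or still open speak of the compounds shown alone.

Working notes on a small set of amides built on the shared core of compound 1 `CC(=O)N1CC2CC(C1)N2`. In an assay on SH-EP1 cells for displacement of a labelled ligand from Neuronal acetylcholine receptor; alpha4/beta2 (Homo sapiens), read by scintillation counting (on this read-out higher numbers stand for weaker inhibition and lower numbers for stronger inhibition), compound 1 gives 150 nM, the highest number of the three measured. Compound 2 `CC(C)C(=O)N1CC2CC(C1)N2` gives 130 nM in this assay, and the step of a 1.2-fold lower number from compound 1 to compound 2 (0.06 log units; within the scatter) lies within the scatter, so the two read as equal. Compound 3 `C[C@@H]1C[C@@H]1C(=O)N1CC2CC(C1)N2` gives 22 nM, with the steps of a 6.8-fold lower number from compound 1 to compound 3 (0.83 log units; beyond the scatter) and a 5.9-fold lower number from compound 2 to compound 3 (0.77 log units; beyond the scatter) both beyond the scatter.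

Compound 4 `C[C@H]1C[C@@H]1C(=O)N1CC2CC(C1)N2` carries the change (2-methylcyclopropyl in place of methyl on a carbonyl carbon). It shares the 2-methylcyclopropyl group with compound 3 and differs from it only in the arrangement of its 2 defined stereocentres. Among the measured compounds shown here, the step that bears most directly is the one from compound 1 to compound 3 in this assay, a modest gain; the step from compound 2 to compound 3 points the same way. For the measured compounds named here, no measured pair shows what a change of arrangement at the stereocentres does, so compound 4 is placed near compound 3 with a wider allowance.

Compound 4 is therefore expected to give 35 nM in this assay, within 12 nM to 110 nM, a step estimated as a 4.3-fold lower number from compound 1 to compound 4 (0.63 log units; beyond the scatter).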

Compound 4, inhibition constant: 17 nM
Compound 4: the middle estimate sits 2.1-fold (0.31 log units) above what was measured, within the range that was stated.
By their numbers in this assay, from the lowest: compounds 4 and 3 (each within the scatter of the next); then compounds 2 and 1 (each within the scatter of the next).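

In this assay the new information is the arrangement at the stereocentres: a 1.3-fold lower number from compound 3 to compound 4 (0.11 log units; within the scatter) is a step within the scatter, so compounds 3 and 4 read as equal and the gain does not depend on which of these two arrangements is drawn. The 2-methylcyclopropyl gain therefore now rests on two compounds rather than one, with an 8.8-fold lower number from compound 1 to compound 4 (0.95 log units; beyond the scatter) and a 7.6-fold lower number from compound 2 to compound 4 (0.88 log units; beyond the scatter) as steps both beyond the scatter, and compounds 3 and 4 both stand apart from the methyl and isopropyl amides on the carbonyl carbon. The equality of compounds 3 and 4 needs one caveat on how far it speaks to stereochemistry: the fact that one of compounds 3 and 4 is drawn with a defined configuration and the other without, at the place where they differ.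

Still open is how much of the gain belongs to the three-membered ring itself, since the unsubstituted cyclopropyl amide is absent from the compounds shown, and whether the remaining arrangements of 2-methylcyclopropyl read the same. Also open, on these data alone, is how this position responds to a larger ring such as cyclobutyl, to a phenyl ring, or to an amine carried on the ring.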